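This account rests on a few compounds, and the source may have more. Where it says the series, first, only, none or still open, it means among the compounds named here.

Compound 1 `CN1[C@@H]2c3[nH]c4ccccc4c3C[C@H]1[C@H](C#N)N1[C@@H](CNC(=O)c3ccc4ccccc4n3)c3[nH]c4ccccc4c3C[C@@H]21`: 150 nM
Compound 2 `CN1[C@@H]2c3[nH]c4ccccc4c3C[C@H]1[C@H](C#N)N1[C@@H](CNC(=O)c3cc4ccccc4o3)c3[nH]c4ccccc4c3C[C@@H]21`: 320 nM

In a functional assay on MCF7 cells (Homo sapiens) for cytotoxicity, read by MTT assay, with a stated time of 72 h (a higher number here means a weaker inhibitor, a lower number a stronger inhibitor), compound 2 stands with the higher of the two measured numbers, and its nearest neighbour is compound 1, separated by a step of a 2.1-fold higher number from compound 1 to compound 2 (0.33 log units; beyond the scatter). Compound 3 `CN1[C@@H]2c3[nH]c4ccccc4c3C[C@H]1[C@H](C#N)N1[C@@H](CNC(=O)c3cc4ccccc4[nH]3)c3[nH]c4ccccc4c3C[C@@H]21` differs from compound 2 only in that (1H-indol-2-yl in place of 1-benzofuran-2-yl on a carbonyl carbon). Going by the values given here, the single measured step, a 2.1-fold higher number from compound 1 to compound 2 (0.33 log units; beyond the scatter), concerns a different exchange at the same carbonyl carbon, so it bears on this change only loosely; a modest step in either direction is expected. Compound 3 is therefore estimated at 250 nM, within the range 100 nM to 700 nM, an expected step of a 1.3-fold lower number from compound 2 to compound 3 (0.11 log units; within the scatter).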

Compound 3, half-maximal inhibitory concentration: 9780 nM
Compound 3: middle estimate off by 39-fold (1.59 log units), on the low side; measured number outside the range, above it.
By their numbers in this assay, from the lowest: compound 1; then compound 2; then compound 3.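

In this assay, this carbonyl position proves far more sensitive than the first pair suggested: 1H-indol-2-yl in place of 1-benzofuran-2-yl, with the same count of heavy atoms and one ring atom changed, gives a 31-fold higher number from compound 2 to compound 3 (1.49 log units; beyond the scatter). The same group in place of quinolin-2-yl gives a 65-fold higher number from compound 1 to compound 3 (1.81 log units; beyond the scatter). Nothing available explains this sharp loss of potency. The compounds shown leave open whether the hydrogen on the indole nitrogen is tied to the loss. A 1-methyl-1H-indol-2-yl group on the same carbonyl carbon would bear on that question.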